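A few compounds are considered here, and "the series" means these few. Any claim that something is new, unique, unknown or untested is made for them only; others in the source may bear on it.

Measured so far in a physicochemical assay for acid dissociation:
- Compound 1, `CC(C)Cc1ccc2c(NCCCNCc3ccco3)ccnc2c1`, gives 9.47.
- Compound 2, `c1ccc(-c2ccc3c(NCCCNCc4ccco4)ccnc3c2)cc1`, gives 9.47.
- Compound 3, `Fc1ccc(Cc2ccc3c(NCCCNCc4ccco4)ccnc3c2)c(Cl)c1`, gives 9.47.

Compound 3 stands level with compounds 1 and 2 at the digits printed: the step of no change at the digits printed from compound 1 to compound 3 (within the scatter) and the step of no change at the digits printed from compound 2 to compound 3 (within the scatter) both lie within the scatter, as does the step of no change at the digits printed from compound 1 to compound 2 (within the scatter) between the other two. Across all three measured compounds, replacing the group on the aromatic carbon of the shared core has left this assay unmoved.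

Compound 4, `FC(F)(F)c1ccc(-c2ccc3c(NCCCNCc4ccco4)ccnc3c2)cc1`, is not yet measured. It differs from compound 3 by 4-(trifluoromethyl)phenyl in place of 2-chloro-4-fluorobenzyl on an aromatic carbon. Every measured step at this same position bears on it, and each of them was flat within the scatter. The expectation for compound 4 is therefore a step of no size beyond the scatter, no change at the digits printed from compound 3 to compound 4 (within the scatter), in no particular direction. Compound 4 is estimated at 9.47, within a range from 9.15 to 9.8.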

Compound 4, acid dissociation constant: 9.47
Compound 4: middle estimate and measured number agree at the digits printed; the measured number falls inside the stated range.
By their numbers in this assay, from the lowest: compounds 1, 2, 3 and 4 (each within the scatter of the next).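

In this assay, 4-(trifluoromethyl)phenyl in place of 2-chloro-4-fluorobenzyl gives no change at the digits printed from compound 3 to compound 4 (within the scatter), and the same group in place of isobutyl gives no change at the digits printed from compound 1 to compound 4 (within the scatter), so a fourth group at this place on the shared core joins the flat set. The new kind of change is one within the aryl group rather than an exchange of the whole group: trifluoromethyl in place of hydrogen on an aromatic carbon gives no change at the digits printed from compound 2 to compound 4 (within the scatter). Nothing shown accounts for this flat result.

The compounds shown leave open whether an amine or a carboxylic acid at this same place would also leave this assay unmoved. They also leave open whether a longer chain elsewhere on the shared core would do so.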